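A cyclopropyl amide among three measured analogues

The source may report more compounds than this note shows. Statements on the series, on what has been measured and on what is new or still open speak of the compounds shown alone.

Of the compounds shown here, three built on one shared core have been measured in an ADME assay on Vero cells (Chlorocebus sabaeus) for cytotoxicity, read by MTT assay, with a stated time of 72 h; on this read-out higher numbers stand for weaker inhibition and lower numbers for stronger inhibition. Compound 1 `O=C(Nc1nc(-c2ccccc2)cs1)c1ccc([N+](=O)[O-])o1` gives 41700 nM; compound 2 `CC(C)Oc1cccc(-c2csc(NC(=O)c3ccc([N+](=O)[O-])o3)n2)c1` gives 69500 nM; compound 3 `CC(=O)Nc1cccc(-c2csc(NC(=O)c3ccc([N+](=O)[O-])o3)n2)c1` gives 57600 nM. Compound 3 stands second highest of the three numbers, nearest to compound 2 and furthest from compound 1, with a 1.2-fold lower number from compound 2 to compound 3 (0.08 log units; within the scatter) and a 1.4-fold higher number from compound 1 to compound 3 (0.14 log units; within the scatter) both inside the scatter. Compound 4 `O=C(Nc1nc(-c2cccc(NC(=O)C3CC3)c2)cs1)c1ccc([N+](=O)[O-])o1` differs from compound 3 by cyclopropyl in place of methyl on a carbonyl carbon. Among the measured compounds shown here, no measured step touches this carbonyl carbon; the steps that exist, a 1.7-fold higher number from compound 1 to compound 2 (0.22 log units; within the scatter) and a 1.4-fold higher number from compound 1 to compound 3 (0.14 log units; within the scatter), concern the aromatic carbon and stayed inside the scatter. Nothing here points to a move beyond the scatter in this assay. Compound 4 is therefore expected to give about 60000 nM, within 30000 nM to 120000 nM, a step of a 1.0-fold higher number from compound 3 to compound 4 (0.02 log units; within the scatter).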

Compound 4, half-maximal inhibitory concentration: 35700 nM
Estimate against measurement, compound 4: 1.7-fold (0.23 log units) above, within the range that was stated.
By their numbers in this assay, from the lowest: compounds 4, 1, 3 and 2 (each within the scatter of the next).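

Cyclopropyl in place of methyl on a carbonyl carbon, a position no earlier step had touched, gives a step within the scatter in this assay (a 1.6-fold lower number from compound 3 to compound 4 (0.21 log units; within the scatter)). The whole (cyclopropylcarbonyl)amino group also stays within the scatter, whether it replaces isopropoxy (a 1.9-fold lower number from compound 2 to compound 4 (0.29 log units; within the scatter)) or hydrogen (a 1.2-fold lower number from compound 1 to compound 4 (0.07 log units; within the scatter)) on an aromatic carbon. No measurement available here bears on the reason for this result. As far as these compounds go, whether a longer chain, an amine or a carboxylic acid on this carbonyl carbon would produce a step beyond the scatter remains open.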